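From a Fluoro-Methoxy Aryl to a Nitrophenyl Cinnamamide

A few compounds are considered here, and "the series" means these few. Any claim that something is new, unique, unknown or untested is made for them only; others in the source may bear on it.

Compound 2 `COc1cc(/C=C/C(=O)Nc2cc(C(=O)c3cc(OC)c(OC)c(OC)c3)ccc2OC)ccc1F` is one of two cinnamamides measured in a functional assay on HT-29 cells (Homo sapiens) for cytotoxicity, read by MTT assay, with a stated time of 72 h; on this read-out lower numbers stand for stronger inhibition and higher numbers for weaker inhibition. Compound 1 `COc1ccc(C(=O)c2cc(OC)c(OC)c(OC)c2)cc1NC(=O)/C=C/c1cc(OC)c(OC)c(OC)c1` gives 3100 nM there, and compound 2 gives 7700 nM, the highest of the two numbers. The step between them, a 2.5-fold higher number from compound 1 to compound 2 (0.40 log units; beyond the scatter), is a modest loss beyond the scatter. Compound 3 `COc1ccc(C(=O)c2cc(OC)c(OC)c(OC)c2)cc1NC(=O)/C=C/c1ccc([N+](=O)[O-])cc1` differs from compound 2 by 4-nitrophenyl in place of 4-fluoro-3-methoxyphenyl on a double-bonded chain carbon bound to a double-bonded chain carbon. Among the compounds with values here, only one measured step bears on this change, the earlier swap of the aryl on the chain carbon, a 2.5-fold higher number from compound 1 to compound 2 (0.40 log units; beyond the scatter), and it involved a different pair of groups, so it sets the likely size of such a swap rather than its direction. A step of about that size in this assay, in either direction or none beyond the scatter, is expected. Compound 3 is therefore estimated at 9000 nM, within 2500 nM to 30000 nM. For compound 3 this means an expected step of a 1.2-fold higher number from compound 2 to compound 3 (0.07 log units; within the scatter).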

Compound 3, half-maximal inhibitory concentration: 5100 nM
Compound 3: the middle estimate sits 1.8-fold (0.25 log units) above what was measured; low and high end bracket the measured number.
By their numbers in this assay, from the lowest: compounds 1, 3 and 2 (each within the scatter of the next, the first and the last beyond it).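

With compound 3, an aryl group carrying no methoxy group stands on the double-bonded chain carbon, and the number stays within the scatter of both earlier compounds: a 1.5-fold lower number from compound 2 to compound 3 (0.18 log units; within the scatter), and a 1.6-fold higher number from compound 1 to compound 3 (0.22 log units; within the scatter). In this assay, this position therefore accepts 4-nitrophenyl in place of either methoxy-bearing aryl group without a step beyond the scatter, and among the three compounds only a 2.5-fold higher number from compound 1 to compound 2 (0.40 log units; beyond the scatter) lies beyond it. No measurement shown here accounts for these steps.

The compounds shown leave open whether an amine or a carboxylic acid in place of the nitro group would keep the number in this range. They also leave open whether a simple methyl group could stand in place of the aryl ring on this chain carbon.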